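This account rests on a few compounds, and the source may have more. Where it says the series, first, only, none or still open, it means among the compounds named here.

This account follows a small set of compounds tested in a functional assay on HL-60 cells (Homo sapiens) for inhibition, read by MTT assay, with a stated time of 72 h; on this read-out lower numbers stand for stronger inhibition and higher numbers for weaker inhibition. There, compound 1 `Cc1nc(-c2ccccc2F)c(C(=O)N2CCN(c3cc(Cl)ccc3C)CC2)o1` gives 229 nM, the lower of the two numbers available. Compound 3 `CCc1nc(-c2ccc(C(C)C)cc2)c(C(=O)N2CCN(c3cccc(OC)c3)CC2)o1` gives 887 nM, and that gap lies beyond the usual scatter of repeated measurements, so compound 1 is the stronger of the pair. Compound 2 `Cc1nc(-c2ccc(Cl)cc2)c(C(=O)N2CCN(c3cccc(C(=O)C(C)C)c3)CC2)o1` is recorded as "not active" (no number reported), which offers no number to compare.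

Compound 4 `Cc1nc(-c2ccccc2F)c(C(=O)N2CCN(c3cc(F)cc(F)c3)CC2)o1` has not yet been measured. It keeps the core of compound 1 and changes one group: 3,5-difluorophenyl in place of 5-chloro-2-methylphenyl on an amine nitrogen in a ring. Among the compounds with values here, no two measured compounds differ in just one place, so the data give no direct measure of what such a swap does. The expectation therefore rests on little. Within the data shown here, compound 1, at 229 nM, holds the lowest number so far, and a new compound seems more likely to land above it than below it. A modest move toward a higher number is expected, near the edge of the usual scatter.

The estimated change is a 2.2-fold higher number from compound 1 to compound 4 (0.34 log units; beyond the scatter). In this assay the expected value for compound 4 is 500 nM, with an estimated range from 140 nM to 1800 nM.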

Compound 4, half-maximal inhibitory concentration: 186 nM
Compound 4: the middle estimate sits 2.7-fold (0.43 log units) above what was measured; the measured number falls inside the stated range.
By their numbers in this assay, from the lowest: compounds 4 and 1 (each within the scatter of the next); then compound 3.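

In this assay, within the data shown here, compounds 1 and 4 form the first pair in this set that differs in only one place, so the effect of a change on the amine nitrogen in a ring can now be read directly. Putting 3,5-difluorophenyl in place of 5-chloro-2-methylphenyl gives a 1.2-fold lower number from compound 1 to compound 4 (0.09 log units; within the scatter), so the two compounds cannot be told apart on this read-out. At this position, then, a ring bearing a chlorine and a methyl group and a ring bearing two fluorines give numbers that are indistinguishable, even though the two groups share the same count of heavy atoms and the same kind of aromatic ring; nothing available explains why they read alike.

This single pair cannot show how much freedom the position allows, and a plain phenyl or a phenyl bearing an amine or a carboxylic acid could give a very different number. From the compounds shown here alone, whether the same swap would read alike on a different core also remains open, as does the effect of each substituent taken alone.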